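Cyclopropyl in place of a methylpyridyl on a benzothiophene agonist

The source may hold more compounds than are shown below. What is called first, only, known or untested is meant among the compounds shown, and "the series" means these compounds.

Measured compounds:
Compound 1 `CC#C[C@@H](Cc1nnn[nH]1)c1ccc(OCc2ccc3scc(-c4cccnc4C)c3c2)cc1` gives 88 nM in a functional assay on cells for agonist activity at Free fatty acid receptor 1 (Homo sapiens), read by FLIPR and calcium flux; a higher number here means that more compound is needed for the effect, a lower number that less compound is needed.
Compound 2 `CC#C[C@@H](Cc1nnn[nH]1)c1ccc(OCc2ccc3scc(-c4ccc(OCCCS(C)(=O)=O)cc4C)c3c2)cc1` gives 12 nM.
Compound 3 `CC#C[C@@H](Cc1nnn[nH]1)c1ccc(OCc2ccc3sc(I)c(-c4ccccc4C)c3c2)cc1` gives 28 nM.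

Among these three, compound 1 carries the highest number. Compound 3 stands nearest to it, with a lower number that lies beyond the scatter; compound 2 stands furthest, with the lowest number of the set, also beyond the scatter. The unmeasured compound 4 `CC#C[C@@H](Cc1nnn[nH]1)c1ccc(OCc2ccc3scc(C4CC4)c3c2)cc1` differs from compound 1 in one place: cyclopropyl in place of 2-methylpyridin-3-yl on an aromatic carbon. For the measured compounds named here, no measured pair shows this exact change, so its size can only be estimated. Both substituents that gave lower numbers than compound 1 were six-membered aromatic rings, and a small non-aromatic ring departs from that pattern. Compound 4 is therefore expected to give a higher number, 300 nM, within 80 nM to 1500 nM, the step of a 3.4-fold higher number from compound 1 to compound 4 (0.53 log units; beyond the scatter) being an estimate beyond the scatter.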

Compound 4, half-maximal effective concentration: 858 nM
The estimate for compound 4 lay 2.9-fold (0.46 log units) below the measured number; the measured number falls inside the stated range.
By their numbers in this assay, from the lowest: compound 2; then compound 3; then compound 1; then compound 4.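

In this assay, the aromatic carbon two ring bonds from the ring sulfur responds strongly to this exchange: cyclopropyl in place of 2-methylpyridin-3-yl gives a 9.8-fold higher number from compound 1 to compound 4 (0.99 log units; beyond the scatter). For the compounds shown here, the earlier compounds all carried a six-membered aromatic ring at this carbon and offered no step that changed one place only, so this is the first direct reading at this position. Nothing available accounts for the size of the step. The compounds shown leave open whether ring size or aromatic character matters more here; a cyclohexyl group at this carbon would separate the two.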